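The source may hold more compounds than are shown below. What is called first, only, known or untested is meant among the compounds shown, and "the series" means these compounds.

Working notes on the series. Compound 1 `CNC(=O)c1cccnc1NCCCN1CCN(c2ccccc2OC)CC1` and compound 2 `CN(C)C(=O)c1cccnc1NCCCN1CCN(c2ccccc2OCC2CC2)CC1` have been measured in a functional assay on aorta for antagonist activity at Alpha-1D adrenergic receptor (Rattus norvegicus); on this read-out higher numbers stand for weaker binding and lower numbers for tighter binding. In this assay compound 1 gives 3.16 nM, and compound 2 gives 10 nM. Compound 2 thus stands at the higher of the two numbers, with compound 1 sitting well below it, a gap that lies beyond the usual scatter; as the two compounds differ in more than one place, their two values are recorded side by side without further reading.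

Compound 3 `CN(C)C(=O)c1cccnc1NCCCN1CCN(c2ccccc2Cc2ccccc2)CC1` has not yet been measured in this assay. It differs from compound 2 in one place: benzyl in place of cyclopropylmethoxy on an aromatic carbon. Benzyl in place of cyclopropylmethoxy removes the single hydrogen-bond acceptor of the group that leaves while adding two heavy atoms. Within the data shown here, no measured pair shows what such a change does, so the expected step from compound 2 to compound 3 is a modest weakening, a 2.0-fold higher number from compound 2 to compound 3 (0.30 log units; within the scatter), near the edge of the scatter. For compound 3 in this assay the estimate is 20 nM, with a range from 6 nM to 60 nM.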

Compound 3, dissociation constant: 79.4 nM
Estimate against measurement, compound 3: 4.0-fold (0.60 log units) below; measured number outside the range, above it.
By their numbers in this assay, from the lowest: compound 1; then compound 2; then compound 3.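

In this assay, among these compounds, the exchange of cyclopropylmethoxy for benzyl on an aromatic carbon, ortho to a large group, gives a 7.9-fold higher number from compound 2 to compound 3 (0.90 log units; beyond the scatter) and is the first single-place step to be read; it shows that the group at this position can move the number beyond the scatter. Several things change at once in this step: the hydrogen-bond acceptor leaves, the heavy-atom count rises, and a six-membered aromatic ring replaces a three-membered non-aromatic ring, and one step cannot separate these differences. No available measurement bears on what lies behind the higher number for compound 3.

The compounds shown leave open whether benzyloxy or phenoxy, which keep an oxygen on the aromatic carbon while carrying an aromatic ring, would stay closer to compound 2 than benzyl does, and whether cyclopropylmethyl, which keeps the three-membered ring without the oxygen, would follow compound 3. They also leave open how much of the gap between compound 1 and compound 2 belongs to the amide and how much to the ether group.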